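Swapping Fluoro for Methoxy on the Shared Core

This account rests on a few compounds, and the source may have more. Where it says the series, first, only, none or still open, it means among the compounds named here.

Three measured compounds share a diaryl urea core and differ only in one group on the fused ring system. Compound 1 `O=C(Nc1ccc(-n2ncc3c(Br)cccc32)cc1)Nc1ccc(Cl)c(C(F)(F)F)c1` carries a bromo there, and in a functional assay on LoVo cells (Homo sapiens) for cytotoxicity, read by MTT assay, with a stated time of 72 h (a lower number here means a stronger inhibitor, a higher number a weaker inhibitor), compound 1 gives 1700 nM. Compound 2 `O=C(Nc1ccc(-n2ncc3c(F)cccc32)cc1)Nc1ccc(Cl)c(C(F)(F)F)c1` carries a fluoro instead, and in this assay compound 2 gives 9800 nM, the highest of the three numbers. Compound 3 `CNc1cccc2c1cnn2-c1ccc(NC(=O)Nc2ccc(Cl)c(C(F)(F)F)c2)cc1` carries a methylamino, and in this assay compound 3 gives 6300 nM.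

The recorded steps are a 5.8-fold higher number from compound 1 to compound 2 (0.76 log units; beyond the scatter) and a 3.7-fold higher number from compound 1 to compound 3 (0.57 log units; beyond the scatter), both beyond the scatter, whereas a 1.6-fold lower number from compound 2 to compound 3 (0.19 log units; within the scatter), which lies within the scatter.

Compound 4 `COc1cccc2c1cnn2-c1ccc(NC(=O)Nc2ccc(Cl)c(C(F)(F)F)c2)cc1` has not yet been measured. Its difference from compound 2 is this: methoxy in place of fluoro on an aromatic carbon. For the measured compounds named here, the step that bears most directly on it is the one from compound 2 to compound 3, which also replaced the same fluoro and moved the number only a 1.6-fold lower number from compound 2 to compound 3 (0.19 log units; within the scatter). On that basis a step in this assay of no more than modest size, if any, is expected, most likely toward a lower number. The step from compound 2 to compound 4 is therefore expected to be a 1.6-fold lower number from compound 2 to compound 4 (0.21 log units; within the scatter). Compound 4 is estimated to give 6000 nM in this assay, with a likely range from 2500 nM to 14000 nM.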

Compound 4, half-maximal inhibitory concentration: > 32000 nM
Compound 4: only a limit was reported; the forecaster's own chance of this, stated with the estimate: 5%; middle value at least 5.3-fold (0.72 log units) from the limit.
By their numbers in this assay, from the lowest: compound 1; then compounds 3 and 2 (each within the scatter of the next). At a limit, above all of these: compound 4.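

In this assay, compound 4 has a limit rather than a number: the limit of > 32000 nM in this assay, at which 1 of the 4 values shown sits. Even so, the steps are already clear, and all three lie beyond the scatter: an at least 3.2-fold higher number from compound 2 to compound 4 (0.51 log units; beyond the scatter), an at least 5.0-fold higher number from compound 3 to compound 4 (0.70 log units; beyond the scatter) and an at least 18-fold higher number from compound 1 to compound 4 (1.27 log units; beyond the scatter). The earlier compounds shown here left the impression that replacing the fluoro at this aromatic carbon changes little, given a 1.6-fold lower number from compound 2 to compound 3 (0.19 log units; within the scatter), but methoxy shows that this single position can also separate a compound clearly from all three others, so the effect depends strongly on which group enters and not merely on the fact of a change.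

The compounds shown leave open whether this weakening belongs to methoxy alone or extends to other groups joined through oxygen, such as ethoxy or hydroxyl, and whether a chloro or a plain hydrogen at the same carbon would fall nearer compound 1 or compound 2. The limit also leaves the full size of each new step unknown, so these steps give only a lower bound on how far compound 4 stands from the others.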